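This account rests on a few compounds, and the source may have more. Where it says the series, first, only, none or still open, it means among the compounds named here.

Values so far in a functional assay on HepG2 cells (Homo sapiens) for cytotoxicity; on this read-out higher numbers stand for weaker inhibition and lower numbers for stronger inhibition:
- compound 1 `C=C1CC[C@@H](C(=O)C(C)C)[C@H]2[C@@]1(C)[C@@H](O)C(=O)C(=C)[C@]2(C)C[C@@H](OC(=O)/C(C)=C/C)[C@]1(O)COC(=O)C1` gives 2.06 ug/mL
- compound 2 `C=C1CC[C@@H](C(=O)/C(C)=C/C)[C@H]2[C@@]1(C)[C@@H](O)C(=O)C(=C)[C@]2(C)C[C@@H](OC(=O)/C(C)=C/C)[C@]1(O)COC(=O)C1` gives 3.09 ug/mL

Among the measured compounds shown here, compound 2 stands level with compound 1, the only other measured compound, as the two values lie within the scatter of each other and set no order. The next compound is compound 3 `C=C1CC[C@@H](C(=O)C(C)CC)[C@H]2[C@@]1(C)[C@@H](O)C(=O)C(=C)[C@]2(C)C[C@@H](OC(=O)/C(C)=C/C)[C@]1(O)COC(=O)C1`, with sec-butyl in place of 1-methylprop-1-en-1-yl on a carbonyl carbon. The rest of the structure stays the same.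

For the measured compounds named here, one measured step bears on this change, and it sits at the same place: a 1.5-fold higher number from compound 1 to compound 2 (0.18 log units; within the scatter), with 1-methylprop-1-en-1-yl in place of isopropyl. Going by the values given here, a single step is a thin basis, and no measured compound yet carries sec-butyl. Even so, with that one change at this place staying within the scatter, no step beyond the scatter is expected in this assay. The expected change is a 1.2-fold lower number from compound 2 to compound 3 (0.09 log units; within the scatter), an estimate that stays within the scatter. Compound 3 is estimated at 2.5 ug/mL, with an expected range from 1.2 ug/mL to 5.2 ug/mL.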

Compound 3, half-maximal inhibitory concentration: 2.1 ug/mL
Beside the measured number, compound 3's estimate is 1.2-fold (0.08 log units) above it; measured number inside the range.
By their numbers in this assay, from the lowest: compounds 1, 3 and 2 (each within the scatter of the next).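

Sec-butyl in place of 1-methylprop-1-en-1-yl on a carbonyl carbon gives, in this assay, a 1.5-fold lower number from compound 2 to compound 3 (0.17 log units; within the scatter), so losing the double bond outside aromatic rings, with the count of 4 carbon atoms in the group unchanged, does not take the read-out beyond the scatter. Methyl in place of hydrogen on a saturated chain carbon, two bonds along the chain from a carbonyl carbon, gives a 1.0-fold higher number from compound 1 to compound 3 (0.01 log units; within the scatter), so the saturated pair of isopropyl and sec-butyl cannot be told apart here, and all three groups at this place now stand level in this assay. No measurement offered alongside these values accounts for this flat picture.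

The compounds shown leave open whether any group at this place can move the number beyond the scatter, since all three carry only carbon and hydrogen there, and a phenyl ring, a longer chain or an amine on this carbonyl carbon would put that to the test. The rest of the structure is the same in all three compounds, so they say nothing about how changes elsewhere on the shared core would read in this assay.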